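A few compounds are considered here, and "the series" means these few. Any claim that something is new, unique, unknown or untested is made for them only; others in the source may bear on it.

Compound 1, with the structure `Oc1ccc(-c2cc(-c3cccnc3)nc(-c3ccccc3Cl)c2)cc1`, is one of three analogues that share a common core and a 4-hydroxyphenyl group. Its close relative compound 2, `Oc1ccc(-c2cc(-c3ccccn3)nc(-c3ccccc3Cl)c2)cc1`, and compound 3, `Oc1ccc(-c2cc(-c3ccsc3)nc(-c3ccccc3Cl)c2)cc1`, complete the set of measured entries. In an ADME assay on HEK293 cells (Homo sapiens) for cytotoxicity, read by CCK-8 assay and cell counting, with a stated time of 2 days (a lower number here means a stronger inhibitor, a higher number a weaker inhibitor), compound 3 gives 5930 nM. In this assay compound 1 gives "not determined" (no result reported) and compound 2 gives "not determined" (no result reported), so compound 1 stands without a single number of its own, and one further entry in the series likewise lacks one. From the compounds shown here alone, no comparison between two measured compounds that differ in a single place is available, so the size of any structural effect in this assay remains open.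

Compound 4, `Oc1ccc(-c2cc(-c3ccc(Cl)cc3)nc(-c3cccnc3)c2)cc1`, is the compound still to be tested. It differs from compound 1 in one place: 4-chlorophenyl in place of 2-chlorophenyl on an aromatic carbon. Within the data shown here, with no measured pair to anchor the step, the only reference is compound 3 at 5930 nM, and a rearrangement of the same atoms in a cytotoxicity read-out would be expected to stay within the usual scatter rather than to move the number in either direction. Compound 4 is therefore estimated to give about 6000 nM in this assay, with a plausible range from 2000 nM to 20000 nM.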

Compound 4, half-maximal inhibitory concentration: 27500 nM
Estimate against measurement, compound 4: 4.6-fold (0.66 log units) below; measured number outside the range, above it.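

In this assay, among these compounds, compound 4 gives 27500 nM and compound 1 gives "not determined" (no result reported) as its entry, so no step between compound 1 and compound 4 can be read. The compounds shown leave open what 4-chlorophenyl in place of 2-chlorophenyl does to the value, and no measured evidence bears on this result.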